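The source may report more compounds than this note shows. Statements on the series, on what has been measured and on what is new or still open speak of the compounds shown alone.

Of the compounds shown here, two built on a shared core have so far been tested in an ADME assay on MT4 cells (Homo sapiens) for cytotoxicity, with a stated time of 5 days; a higher number here means that more compound is tolerated, a lower number that less compound is tolerated. Among the compounds with values here, compound 1, `CON=C1CCC(N(c2cc(C#CC(C)(C)C)sc2C(=O)O)C(=O)[C@H]2CC[C@H](C)CC2)CC1`, is the first of them. In this assay compound 1 gives > 20000 nM, which is a limit of the assay rather than a number. Compound 2, `CC(C)(C)C#Cc1cc(N(C(=O)[C@H]2CC[C@H](C)CC2)[C@H]2CC[C@@H](Oc3ccc(=O)[nH]n3)CC2)c(C(=O)O)s1`, is the second. In this assay compound 2 gives > 20000 nM, again a limit and not a number. Compound 2 therefore stands exactly where every value shown stands, since (the limit of > 20000 nM in this assay, at which 2 of the 2 values shown sit); nothing on these numbers sets it apart from compound 1.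

Compound 3, `CC(C)(C)C#Cc1cc(N(C(=O)[C@H]2CC[C@H](C)CC2)[C@H]2CC[C@@H](Oc3cccnc3)CC2)c(C(=O)O)s1`, has not yet been measured. It differs from compound 2 in one place: a group of 6 heavy atoms (5 carbon, 1 nitrogen; one six-membered aromatic ring with 1 hetero atom) in place of a group of 7 heavy atoms (4 carbon, 2 nitrogen, 1 oxygen; one six-membered aromatic ring with 2 hetero atoms), on an oxygen on a saturated carbon. The change sits on an oxygen on a saturated carbon, a pyridin-3-yl entering where a six-membered aromatic ring with 2 hetero atoms left.

Within the data shown here, no step between two measured compounds exists in this assay, so there is no measured guide to how large such a change might be. Among the measured compounds shown here, with both values so far at the same limit, the step this estimate means, a number no higher from compound 2 to compound 3 (the limit leaves the size open), is expected to be none beyond the scatter. Compound 3 is accordingly estimated at 20000 nM, within a range from 10000 nM to 40000 nM, with a good chance that this assay again reports only a limit.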

Compound 3, half-maximal cytotoxic concentration: > 20000 nM
Compound 3: no number, only a limit (the forecaster's own chance of this, stated with the estimate: 80%); the middle value lies on the limit itself.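

No size can be read for the change from compound 2 to compound 3, because each gives only a limit and not a number: the limit of > 20000 nM in this assay, at which 3 of the 3 values shown sit.

The compounds shown leave open at what concentration, if any, compound 1, compound 2 or compound 3 would harm the cells in this assay, and whether swapping the ring on that oxygen changes this.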